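Fluoro in Place of Chloro: An Expected Small Step

The source may hold more compounds than are shown below. What is called first, only, known or untested is meant among the compounds shown, and "the series" means these compounds.

Compound 1 `Cc1nc(-c2ccccc2)c(C(=O)N2CCN(c3cccc(Cl)c3)CC2)o1` holds the only number shown in a functional assay on HL-60 cells (Homo sapiens) for inhibition, read by MTT assay, with a stated time of 72 h (on this read-out higher numbers stand for weaker inhibition and lower numbers for stronger inhibition), where compound 1 gives 39.2 nM. Compound 2 `Cc1nc(-c2cccc(OP(=O)(O)O)c2)c(C(=O)N2CCN(c3cccc(Cl)c3)CC2)o1` reaches only a limit of the assay, > 1000 nM. The measured step of an at least 25-fold higher number from compound 1 to compound 2 (1.40 log units; beyond the scatter) concerns a different change and does not bear on the step to compound 3 `Cc1nc(-c2ccccc2)c(C(=O)N2CCN(c3cccc(F)c3)CC2)o1`, which carries fluoro in place of chloro on an aromatic carbon. Within the data shown here, no measured step speaks to this change, so a step of a 1.5-fold higher number from compound 1 to compound 3 (0.18 log units; within the scatter) is expected, within the scatter. Compound 3 is therefore estimated at 60 nM, with a range from 20 nM to 200 nM.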

Compound 3, half-maximal inhibitory concentration: 45 nM
Beside the measured number, compound 3's estimate is 1.3-fold (0.12 log units) above it; the measured number falls inside the stated range.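

In this assay, the change from 3-chlorophenyl to 3-fluorophenyl gives a step within the scatter (a 1.1-fold higher number from compound 1 to compound 3 (0.06 log units; within the scatter)). The number therefore holds across these two halogens at this position, whereas the earlier compounds had shown only a large step from a change elsewhere in the molecule. Nothing shown gives a cause for this result.

Going by these compounds, whether an amine, a methoxy group or a trifluoromethyl group at this position would keep the number in the same range stays open. So does the effect of removing the halogen altogether.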